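Swapping methoxypyridine for phenyl: an expected clearance shift

This account rests on a few compounds, and the source may have more. Where it says the series, first, only, none or still open, it means among the compounds named here.

In an ADME assay (liver) for metabolic stability, with Liver microsome (Homo sapiens) as the target, read by LC-MS, using microsomes, tested at 1 uM (on this read-out lower numbers stand for slow clearance and higher numbers for fast clearance), three compounds of one series have been measured:
Compound 1 `CNc1nc(NCCCN(C)C)c2sc(-c3ccc(OC)nc3)cc2n1` gives 10 uL/min.
Compound 2 `CNc1nc(NCCCN(C)C)c2sc(-c3cccc4cnccc34)cc2n1` gives 68.7 uL/min.
Compound 3 `CNc1nc(NCCCN(C)C)c2sc(-c3ccoc3)cc2n1` gives 33.3 uL/min.

Compound 1 stands lowest of the three. Compound 3 is nearest to it; compound 2 lies furthest, and its value set against that of compound 1 shows a larger gap still. Compound 4 `CNc1nc(NCCCN(C)C)c2sc(-c3ccccc3)cc2n1` has not yet been tested in this assay. It differs from compound 1 in one place: phenyl in place of 6-methoxypyridin-3-yl on an aromatic carbon. Within the data shown here, the only measured step that bears on this is the one in which a different ring replaced the same 6-methoxypyridin-3-yl on the same aromatic carbon, and the number rose modestly, a 3.3-fold higher number from compound 1 to compound 3 (0.52 log units; beyond the scatter). Compound 2 shows that another replacement there can push the value further up. Of a size roughly like the step to compound 3, a higher number is therefore expected for compound 4, estimated as a 3.0-fold higher number from compound 1 to compound 4 (0.48 log units; beyond the scatter). The estimate for compound 4 is 30 uL/min, in a range from 12 uL/min to 75 uL/min.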

Compound 4, intrinsic clearance in a liver preparation (reported as CLH), per the amount of preparation that the assay uses: 5 uL/min
Estimate against measurement, compound 4: 6.0-fold (0.78 log units) above; measured number outside the range, below it.
By their numbers in this assay, from the lowest: compounds 4 and 1 (each within the scatter of the next); then compound 3; then compound 2.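

In this assay, phenyl in place of 6-methoxypyridin-3-yl on this aromatic carbon next to the ring sulfur gives a 2.0-fold lower number from compound 1 to compound 4 (0.30 log units; within the scatter), so the two compounds cannot be told apart, and the hetero atom and the methoxy group of the group that left are not required for a low number at this position. Phenyl in place of furan-3-yl gives a 6.7-fold lower number from compound 3 to compound 4 (0.82 log units; beyond the scatter), which shows that the rise seen with furan-3-yl does not follow from merely removing 6-methoxypyridin-3-yl. No measurement shown here accounts for the difference between these groups.

The compounds shown leave open whether a plain pyridine ring without the methoxy group, or a phenyl ring carrying a methoxy group or a fluorine, would stay level with compound 4. They also leave open whether the same holds when the dimethylamino chain of the shared core is replaced by a different amine.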